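A few compounds are considered here, and "the series" means these few. Any claim that something is new, unique, unknown or untested is made for them only; others in the source may bear on it.

Measured values in a functional assay on the whole organism (blood, strain Wistar-Okamoto) with Rattus norvegicus as the target, with a stated time of 5 days; on this read-out lower numbers stand for an effect already at smaller amounts and higher numbers for an effect only at larger amounts of compound:
- compound 1 `N#CN/C(=N\C1CC1)Nc1cccnc1`: 20 mg/kg
- compound 2 `CC(C)C(C)(C)/N=C(\NC#N)Nc1cccnc1`: 1 mg/kg
- compound 3 `CCC(C)(CC)/N=C(\NC#N)Nc1cccnc1`: 0.5 mg/kg

Compound 3 has the lowest number of the three. The step of a 2.0-fold lower number from compound 2 to compound 3 (0.30 log units; within the scatter) is within the scatter, so the two are not distinguished; its step from compound 1 is a 40-fold lower number from compound 1 to compound 3 (1.60 log units; beyond the scatter), beyond the scatter.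

Compound 4 `N#CN/C(=N\Cc1ccco1)Nc1cccnc1` is not yet measured. Change: (furan-2-yl)methyl in place of 1-ethyl-1-methylpropyl on a double-bonded nitrogen

Steps that bear on this: a 20-fold lower number from compound 1 to compound 2 (1.30 log units; beyond the scatter) and a 40-fold lower number from compound 1 to compound 3 (1.60 log units; beyond the scatter) show that replacing cyclopropyl, the only ring among the measured groups at this nitrogen, by a branched open chain lowered the number strongly. Compound 4 instead carries a ring again, an aromatic one with a hetero atom, reached through a single carbon. Going by the values given here, no measured step covers an aromatic group here, so the expectation rests on the ring-bearing compound 1 20 mg/kg as the only loose analogue.

Compound 4 is therefore expected to give a higher number than compound 3, with an estimated step of a 10-fold higher number from compound 3 to compound 4 (1.00 log units; beyond the scatter), likely beyond the scatter. The estimate for compound 4 is 5 mg/kg, in the range 1 mg/kg to 30 mg/kg.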

Compound 4, minimum effective dose: 20 mg/kg
For compound 4 the middle estimate is 4.0-fold (0.60 log units) below the measured one; low and high end bracket the measured number.
By their numbers in this assay, from the lowest: compounds 3 and 2 (each within the scatter of the next); then compounds 1 and 4 (each within the scatter of the next).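

In this assay, at the double-bonded nitrogen, (furan-2-yl)methyl falls far from both branched open chains (a 40-fold higher number from compound 3 to compound 4 (1.60 log units; beyond the scatter); a 20-fold higher number from compound 2 to compound 4 (1.30 log units; beyond the scatter)), yet it cannot be told apart from cyclopropyl (no change at the digits printed from compound 1 to compound 4 (within the scatter)). Among these compounds, the two ring-bearing groups now stand together and the two branched open chains stand together, so the earlier gap is not tied to cyclopropyl alone, and no listed compound goes against this split. Nothing measured here explains that split.

Going by these compounds, it remains open whether a straight chain such as n-butyl would sit with compounds 1 and 4 or with compounds 2 and 3. The same question holds for a ring with branching at its attachment carbon, such as 1-methylcyclohexyl, and for a benzyl group.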